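This account rests on a few compounds, and the source may have more. Where it says the series, first, only, none or still open, it means among the compounds named here.

Measured so far:
compound 1 `O=C(Nc1cccc(-n2cc(-c3ccncc3)c(-c3cc(O)cc(Cl)c3)n2)c1)Nc1ccc(Cl)c(Cl)c1` — 72%
compound 2 `COc1cc(Cl)cc(-c2nn(-c3cccc(NC(=O)Nc4cc(C(F)(F)F)cc(C(F)(F)F)c4)c3)cc2-c2ccncc2)c1` — 5%

In a functional assay on PC-3 cells (Homo sapiens) for inhibition, read by sulforhodamine B assay, with a stated time of 48 h, tested at 1 uM (a lower number here means a stronger effect, a higher number a weaker effect of the compound at the concentration tested), compound 2 gives 5%, the lower of the two numbers. Compound 1 gives 72%, a number far higher, well beyond the usual scatter. The two compounds differ in several places at once, so their pair shows only that the series spans a wide range.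

Compound 3 `COc1cc(Cl)cc(-c2nn(-c3cccc(NC(=O)Nc4cccc(C(F)(F)F)c4)c3)cc2-c2ccncc2)c1` is the next compound to be measured. It differs from compound 2 in one place: hydrogen in place of trifluoromethyl on an aromatic carbon. Going by the values given here, no step between measured compounds isolates this change, so its size is uncertain. As one of two trifluoromethyl groups leaves, the expectation is a moderate step upward, toward a weaker effect, from compound 2 to compound 3, a number 20 percentage points higher from compound 2 to compound 3 (beyond the scatter), with a chance that the step stays within the scatter. Compound 3 is estimated at 25%, in a range from 5% to 55%.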

Compound 3, a percentage reported as activity, at one concentration (the size of the read-out at that concentration, not a potency): 27%
For compound 3 the middle estimate is 2 percentage points below the measured one, within the range that was stated.
By their numbers in this assay, from the lowest: compound 2; then compound 3; then compound 1.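

Hydrogen in place of trifluoromethyl on this aromatic carbon gives a number 22 percentage points higher from compound 2 to compound 3 (beyond the scatter) in this assay. Going by these compounds alone, this is the first change read in one place, and it shows that the read-out responds to the group at this position. With one trifluoromethyl group left, compound 3 gives 27%, so the second trifluoromethyl group is not needed for a sizeable effect at the concentration tested. Nothing at hand accounts for the size of this step.

The compounds shown leave open how a nitrile or an amine would read on this carbon, since only trifluoromethyl and hydrogen appear here. Also open, on these data alone, is what the loss of the remaining trifluoromethyl group would do to the read-out, and whether this step holds on other versions of the core.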